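This account rests on a few compounds, and the source may have more. Where it says the series, first, only, none or still open, it means among the compounds named here.

Compound 1 `COC(=O)/C(=C\c1ccc(OC(=O)c2ccccc2)cc1)Sc1ccnc2cc(Cl)ccc12` gives the highest of the three numbers in a functional assay on HL-60 cells (Homo sapiens) for cytotoxicity, read by MTT assay, with a stated time of 24 h (on this read-out higher numbers stand for weaker inhibition and lower numbers for stronger inhibition), at 30200 nM. Compound 2 `COC(=O)/C(=C\c1ccc(OC(=O)c2ccc(OC)cc2)cc1)Sc1ccnc2cc(Cl)ccc12` gives 9090 nM in this assay, and compound 3 `COC(=O)/C(=C\c1ccc(OC(=O)c2cccc(OC)c2)cc1)Sc1ccnc2cc(Cl)ccc12` gives 25500 nM. Compound 4 `COC(=O)/C(=C\c1ccc(OC(=O)c2ccc(OC)c(OC)c2OC)cc1)Sc1ccnc2cc(Cl)ccc12` is not yet measured; relative to compound 1 the change is 2,3,4-trimethoxyphenyl in place of phenyl on a carbonyl carbon. Going by the values given here, two measured steps bear on it, each a methoxy in place of hydrogen on an aromatic carbon: a 3.3-fold lower number from compound 1 to compound 2 (0.52 log units; beyond the scatter), and a 1.2-fold lower number from compound 1 to compound 3 (0.07 log units; within the scatter). Between the two methoxy isomers, a 2.8-fold higher number from compound 2 to compound 3 (0.45 log units; beyond the scatter). The entering group combines methoxy substitution of the kind seen in compound 2 and compound 3, so a lower number beyond the scatter is expected in this assay, about the size seen for compound 2 with 9090 nM. Compound 4 is therefore estimated at 9000 nM, range 3000 nM to 27000 nM, expected step a 3.4-fold lower number from compound 1 to compound 4 (0.53 log units; beyond the scatter).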

Compound 4, half-maximal inhibitory concentration: 2080 nM
For compound 4 the middle estimate is 4.3-fold (0.64 log units) above the measured one, and the stated range ends above it.
By their numbers in this assay, from the lowest: compound 4; then compound 2; then compounds 3 and 1 (each within the scatter of the next).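

In this assay, 2,3,4-trimethoxyphenyl on this carbonyl carbon gives a 15-fold lower number from compound 1 to compound 4 (1.16 log units; beyond the scatter), and the number also falls relative to both single-methoxy isomers, with a 12-fold lower number from compound 3 to compound 4 (1.09 log units; beyond the scatter) and a 4.4-fold lower number from compound 2 to compound 4 (0.64 log units; beyond the scatter). The three methoxy groups together therefore go further at this position than either single methoxy group shown. No measurement here explains this step. Open, going by these compounds, is which of the three methoxy groups accounts for the step, and whether an amine or a carboxylic acid on this phenyl ring would keep the number this low.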